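The compounds below may be only part of what the source reports. "The series", "measured", "known", "first", "only" and "open" are said of these compounds alone.

Measured compounds, with their results in a functional assay on MCF7 cells (Homo sapiens) for cytotoxicity, read by sulforhodamine B assay, with a stated time of 48 h; a higher number here means a weaker inhibitor, a lower number a stronger inhibitor:

compound 1, `CC1=C(/C=C/C(=O)/C=C/c2ccccc2)C(C)(C)CCC1` — compound 1 gives 10600 nM
compound 2, `COc1ccccc1/C=C/C(=O)/C=C/C1=C(C)CCCC1(C)C` — compound 2 gives 13400 nM
compound 3, `COc1ccc(/C=C/C(=O)/C=C/C2=C(C)CCCC2(C)C)cc1OC` — compound 3 gives 35600 nM

All three share a core carrying an aromatic ring that differs only in its methoxy substitution. The one-place step from compound 1 to compound 2 is methoxy in place of hydrogen on an aromatic carbon; it gives a 1.3-fold higher number from compound 1 to compound 2 (0.10 log units; within the scatter), so the two cannot be ordered against each other. The difference between the cores of compound 1 and compound 3 is not broken down here; what the two values show is that compound 3 stands beyond the scatter on the weaker side of both compound 1 and compound 2.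

The unmeasured compound 4, `COc1cc(/C=C/C(=O)/C=C/C2=C(C)CCCC2(C)C)cc(OC)c1OC`, follows from compound 3 by methoxy in place of hydrogen on an aromatic carbon. For the measured compounds named here, this is the same kind of change as the one from compound 1 to compound 2, not the same change: there the entering methoxy sat ortho to a large group, whereas here it sits ortho to a methoxy group, meta to a large group and meta to a methoxy group. Going by the values given here, the only measured step of this kind, a 1.3-fold higher number from compound 1 to compound 2 (0.10 log units; within the scatter), lies within the scatter, and the values of compound 3 and compound 2 point, if anything, toward weaker inhibition as methoxy groups accumulate. On that basis the expected step is a 1.3-fold higher number from compound 3 to compound 4 (0.10 log units; within the scatter), a small drift toward a higher number with wide uncertainty. Compound 4 is accordingly estimated at 45000 nM, within 15000 nM to 120000 nM.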

Compound 4, half-maximal inhibitory concentration: 18700 nM
The estimate for compound 4 lay 2.4-fold (0.38 log units) above the measured number; measured number inside the range.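

In this assay, methoxy in place of hydrogen on an aromatic carbon gives a 1.9-fold lower number from compound 3 to compound 4 (0.28 log units; within the scatter), so the two cannot be ordered against each other. Set beside the earlier step, the change shows no measurable dependence on the core: the same change on two cores in this assay, a 1.3-fold higher number (0.10 log units; within the scatter) from compound 1 to compound 2 and a 1.9-fold lower number (0.28 log units; within the scatter) from compound 3 to compound 4, 2.4-fold (0.38 log units) apart, within the scatter of two such steps. This supports treating the change as having no resolved effect on the number in both pairs, but it does not show that a real effect carries from one core to another, since neither step rises above the scatter, the entering methoxy stands in different surroundings in the two pairs, and two pairs are a narrow base.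

Open, going by these compounds, is whether another group on the aromatic ring, such as hydroxy, an amine or a carboxylic acid, would give a step beyond the scatter on either core. Also open, on these data alone, is whether methoxy in place of hydrogen stays this small on a core with a longer linking chain, or in cells other than those of this assay.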